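Working notes: from compound 1 to compound 3

The compounds below may be only part of what the source reports. "The series", "measured", "known", "first", "only" and "open" are said of these compounds alone.

Compound 1 `COc1ccc([C@H](C)NC(=O)/C(C#N)=C/c2cccc(Br)n2)cc1` gives 1800 nM in a functional assay on OCI-My4 cells (Homo sapiens) for antiproliferative activity, read by MTT assay, with a stated time of 72 h; on this read-out lower numbers stand for stronger inhibition and higher numbers for weaker inhibition
Compound 2 `N#C/C(=C\c1cccc(Br)n1)C(=O)N[C@@H](CO)c1ccccc1` gives 3900 nM in this assay

Within the data shown here, of the two numbers so far, compound 1 holds the lower, and compound 2, the only neighbour, lies higher by more than the usual scatter. Among the measured compounds shown here, these two compounds are not a single-place pair, so no measured step speaks directly to the next change.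

Compound 3 `C[C@H](NC(=O)/C(C#N)=C/c1cccc(Br)n1)c1ccccc1F` has not yet been measured. Its change from compound 1 is 2-fluorophenyl in place of 4-methoxyphenyl on a saturated chain carbon bound to an amide-type nitrogen and a saturated chain carbon, counted as 2-fluorophenyl in place of 4-methoxyphenyl on a saturated chain carbon bound to an amide-type nitrogen and a saturated chain carbon here. For the measured compounds named here, the data hold no measured example of this exchange, so no direction can be supported. The estimated step of a 1.2-fold higher number from compound 1 to compound 3 (0.09 log units; within the scatter) is therefore expected to stay within the scatter of this assay and to show no firm direction. The starting point for this expectation is compound 1 at 1800 nM in the same read-out. For compound 3 the expected value is 2200 nM with an estimated range from 800 nM to 6000 nM in this read-out.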

Compound 3, half-maximal inhibitory concentration: 2400 nM
Compound 3: the middle estimate sits 1.1-fold (0.04 log units) below what was measured, and the stated range covers the measured number.
By their numbers in this assay, from the lowest: compounds 1, 3 and 2 (each within the scatter of the next, the first and the last beyond it).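

At the place on a saturated chain carbon bound to an amide-type nitrogen and a saturated chain carbon, this assay gives the series its first measured single-place step, a 1.3-fold higher number from compound 1 to compound 3 (0.12 log units; within the scatter), for 2-fluorophenyl in place of 4-methoxyphenyl. This exchange takes away the one hydrogen-bond acceptor of the leaving group and still stays within the scatter, so in this single pair neither that acceptor nor the methoxy group shows up as needed to hold the number at this position. No measurement on these compounds bears on why the step is this small.

The exchange alters both the substituent and the place it is printed on the phenyl ring. The compounds shown leave these two changes unseparated, and a plain phenyl group in the same setting would be needed to divide them. Also open, going by these compounds, is how far this position tolerates groups further from these two, such as an amine or a carboxylic acid on the phenyl ring, or a saturated ring such as cyclohexyl in place of the phenyl ring.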